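The source may hold more compounds than are shown below. What is called first, only, known or untested is meant among the compounds shown, and "the series" means these compounds.

In an in vitro ADME assay on microsomes from liver (Homo sapiens) for metabolic stability, tested at 5 uM (on this read-out higher numbers stand for a longer-lived compound and lower numbers for a shorter-lived compound), compound 1 `CC(C)(C)Cn1nc(-c2cccs2)c(O)c(C2=NS(=O)(=O)c3cc(NS(C)(=O)=O)ccc3N2)c1=O` gives > 1 h, which is a limit of the assay and not a number. For the measured compounds named here, compound 2 `CS(=O)(=O)Nc1ccc2c(c1)S(=O)(=O)N=C(c1c(O)c(-c3cccs3)nn(CC3(C(F)(F)F)CCC3)c1=O)N2` gives 1 h, the only exact number so far, which makes it the one firm reference point.

Compound 3 `CS(=O)(=O)Nc1ccc2c(c1)S(=O)(=O)N=C(c1c(O)c(-c3cccs3)nn(Cc3ccccn3)c1=O)N2` keeps the shared core of compound 2 and changes a single group on a saturated chain carbon bound to an aromatic nitrogen, with pyridin-2-yl in place of 1-(trifluoromethyl)cyclobutyl on a saturated chain carbon bound to an aromatic nitrogen.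

Going by the values given here, only one measured step bears on this position, the swap of tert-butyl for 1-(trifluoromethyl)cyclobutyl, which reads a number no higher from compound 1 to compound 2 (the limit leaves the size open). Among the compounds with values here, its size cannot be read, and no measured compound yet carries pyridin-2-yl, so the data point to no clear direction. A step beyond the usual scatter is therefore not expected, and the forecast stays close to compound 2, tilted slightly downward as a cautious guess. The expected change is a 1.3-fold lower number from compound 2 to compound 3 (0.10 log units; within the scatter). For compound 3, the estimated half-life in this assay is 0.8 h, with an expected range of 0.35 h to 1.6 h.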

Compound 3, half-life: > 1 h
Compound 3 ended at the assay's limit (the forecaster's own chance of this, stated with the estimate: 35%); middle value at least 1.2-fold (0.09 log units) from the limit.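

In this assay, putting pyridin-2-yl on a saturated chain carbon bound to an aromatic nitrogen gives a number no lower from compound 2 to compound 3 (the limit leaves the size open), so this swap of a fluorinated ring of carbon only for an aromatic ring holding a nitrogen costs no measurable half-life. Compound 3 gives > 1 h, which is a limit of the assay and not a number. The position therefore accepts a six-membered aromatic ring as well as the tert-butyl and 1-(trifluoromethyl)cyclobutyl groups without a reading under the exact value of compound 2, but the steps that involve the limit on both sides cannot be read, because the compounds concerned stand at the same limit: the limit of > 1 h in this assay, at which 2 of the 3 values shown sit.

As far as these compounds go, how far compound 1 and compound 3 lie past that limit stays open, so any real gap between pyridin-2-yl and tert-butyl remains hidden. Also open, from the compounds shown here alone, is whether a carboxylic acid or an amine such as morpholin-4-yl at this same place would keep the half-life at this level.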